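A Shorter Side Chain on the Shared Core

A few compounds are considered here, and "the series" means these few. Any claim that something is new, unique, unknown or untested is made for them only; others in the source may bear on it.

Of the compounds shown here, three sharing one core have been measured in an assay on isolated protein for binding affinity to 5-hydroxytryptamine receptor 5A (Homo sapiens); on this read-out lower numbers stand for stronger inhibition and higher numbers for weaker inhibition. Compound 1 `CCOCCCNC1=Nc2ccccc2C(C)N1` gives 176 nM, compound 2 `CC1NC(NC[C@H]2CCCO2)=Nc2ccccc21` gives 163 nM, and compound 3 `CC1NC(NCCC2CCCCC2)=Nc2ccccc21` gives 124 nM. Compound 3 carries the lowest of the three numbers, yet both gaps to it fall within the scatter, so the three stand level. Compound 4 `CCCCNC1=Nc2ccccc2C(C)N1` differs from compound 3 by ethyl in place of cyclohexyl on a saturated chain carbon, two bonds along the chain from an amine nitrogen. The step that bears most on this change is a 1.4-fold lower number from compound 1 to compound 3 (0.15 log units; within the scatter), which altered the same position; a 1.1-fold lower number from compound 1 to compound 2 (0.03 log units; within the scatter) was also small. Since swapping groups at this place has so far moved this assay by no more than the scatter, compound 4 is expected to stay near compound 3, with a 1.6-fold higher number from compound 3 to compound 4 (0.21 log units; within the scatter). The estimate for compound 4 is 200 nM, within 90 nM to 450 nM.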

Compound 4, inhibition constant: 189 nM
The estimate for compound 4 lay 1.1-fold (0.02 log units) above the measured number; the range from low to high includes it.
By their numbers in this assay, from the lowest: compounds 3, 2, 1 and 4 (each within the scatter of the next).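

In this assay, ethyl in place of cyclohexyl, an open group of 2 heavy atoms for a ring of 6, gives a 1.5-fold higher number from compound 3 to compound 4 (0.18 log units; within the scatter) and so stays level. The other two steps, a 1.2-fold higher number from compound 2 to compound 4 (0.06 log units; within the scatter) for propyl in place of oxolan-2-yl and a 1.1-fold higher number from compound 1 to compound 4 (0.03 log units; within the scatter) for methyl in place of ethoxy, show that among these four compounds a plain carbon chain matches side chains carrying a ring or an oxygen. Nothing available explains why these changes move the number so little.

Still open, as far as these compounds go, is whether an amine or a carboxylic acid at this place, or a much longer chain, would move the number beyond the scatter.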